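The source may report more compounds than this note shows. Statements on the series, on what has been measured and on what is new or still open speak of the compounds shown alone.

Measured so far in a functional assay on MDA-MB-231 cells (Homo sapiens) for inhibition, read by MTT assay, with stated times of 18 h and 4 h; on this read-out higher numbers stand for weaker inhibition and lower numbers for stronger inhibition:
- compound 1 `CCCCCCCCCCOP(=O)(O)OCCSC(=S)N1CCCCC1`: 24600 nM
- compound 2 `CCCCCCOP(=O)(O)OCCSC(=S)N1CCCCC1`: 85000 nM

Of these two, compound 2 has the higher number, 85000 nM, and so the weaker inhibition. The next compound is compound 3 `CCCCCCCCCCCCCCCCOP(=O)(O)OCCSC(=S)N1CCCCC1`, and its difference from compound 2 is decyl in place of hydrogen on a saturated chain carbon, six bonds along the chain from an oxygen on an unsaturated carbon. Among the measured compounds shown here, only one measured step bears on this change: a 3.5-fold higher number from compound 1 to compound 2 (0.54 log units; beyond the scatter). That step took butyl away at the same place, whereas compound 3 gains decyl there, so the change runs the opposite way and is larger. A lower number than that of compound 2 is therefore expected in this assay. With a single step to go on, the data do not show whether the trend holds for so large a group, so the expected change is kept cautious, at an estimated 9.4-fold lower number from compound 2 to compound 3 (0.98 log units; beyond the scatter). For compound 3 the estimated value is 9000 nM, with an expected range of 2500 nM to 30000 nM.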

Compound 3, half-maximal inhibitory concentration: 100000 nM
Compound 3: the middle estimate sits 11-fold (1.05 log units) below what was measured, and the stated range ends below it.
By their numbers in this assay, from the lowest: compound 1; then compounds 2 and 3 (each within the scatter of the next).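

In this assay, adding decyl to the saturated chain carbon, six bonds along the chain from an oxygen on an unsaturated carbon, gives a 1.2-fold higher number from compound 2 to compound 3 (0.07 log units; within the scatter), so this large addition brings no measurable gain over compound 2. The other new comparison, hexyl in place of hydrogen on a saturated chain carbon, gives a 4.1-fold higher number from compound 1 to compound 3 (0.61 log units; beyond the scatter), which lies beyond the scatter. Lengthening the chain therefore does not lower the number steadily: compound 1 has the lowest number of the three, and compound 3 goes against the trend suggested by the first step.

As far as these compounds go, whether an octyl or dodecyl group would match or better compound 1 remains open. No measured evidence explains this turn in the series.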